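Aryl sulfonate ureas: chain to ring on the amide nitrogen

A few compounds are considered here, and "the series" means these few. Any claim that something is new, unique, unknown or untested is made for them only; others in the source may bear on it.

Measured compounds:
Compound 1, `CC(C)C(=O)Nc1ccc(S(=O)(=O)Oc2ccccc2I)cc1`, 8100 nM
Compound 2, `CCCCCNC(=O)Nc1ccc(S(=O)(=O)Oc2ccccc2I)cc1`, 5400 nM

Compound 2 has been tested in a functional assay on MCF7 cells (Homo sapiens) for antiproliferative activity, read by sulforhodamine B assay, with a stated time of 48 h (a lower number here means a stronger inhibitor, a higher number a weaker inhibitor), where compound 2 gives 5400 nM. Compound 1 differs from it in the group on the carbonyl carbon, and the step is a 1.5-fold lower number from compound 1 to compound 2 (0.18 log units; within the scatter), so the two compounds stand together within the scatter. Compound 3, `O=C(NCC1CCCC1)Nc1ccc(S(=O)(=O)Oc2ccccc2I)cc1`, is the next compound and has not yet been measured. It differs from compound 2 by cyclopentyl in place of butyl on a saturated chain carbon bound to an amide-type nitrogen. For the measured compounds named here, the only measured step, from compound 1 to compound 2, changes the carbonyl substituent and is within the scatter, so there is no measured step on the chain carbon bound to the amide-type nitrogen. For compound 3 the expected step is therefore a 1.1-fold lower number from compound 2 to compound 3 (0.03 log units; within the scatter), with no change beyond the scatter anticipated. Compound 3 is estimated at 5000 nM, expected between 2500 nM and 10000 nM.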

Compound 3, half-maximal inhibitory concentration: 6600 nM
Beside the measured number, compound 3's estimate is 1.3-fold (0.12 log units) below it, and the stated range covers the measured number.
By their numbers in this assay, from the lowest: compounds 2, 3 and 1 (each within the scatter of the next).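

Cyclopentyl in place of butyl on a saturated chain carbon bound to an amide-type nitrogen gives a 1.2-fold higher number from compound 2 to compound 3 (0.09 log units; within the scatter) in this assay, so the first measured change at this position, from an open chain to one carrying a ring, stays within the scatter. Exchanging the whole group on the carbonyl gives a 1.2-fold lower number from compound 1 to compound 3 (0.09 log units; within the scatter), which places compound 3 within the scatter of both compound 1 and compound 2. No available evidence bears on why the chain and the ring read alike here.

On these data alone, whether a benzyl group, a longer chain or a chain carrying an amine in place of cyclopentylmethyl would give a step beyond the scatter remains open. Also open, as far as these compounds go, is whether pentyl and cyclopentylmethyl would read alike on cell lines other than this one.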